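Removing a Chloro Group on a Quinoline-Bearing Macrolide

A few compounds are considered here, and "the series" means these few. Any claim that something is new, unique, unknown or untested is made for them only; others in the source may bear on it.

Compound 1, `CC[C@H]1OC(=O)[C@H](C)[C@@H](O)[C@H](C)[C@@H](O[C@@H]2O[C@H](C)C[C@H](N(C)C)[C@H]2OCCCNC(=O)CNc2ccnc3cc(Cl)ccc23)[C@](C)(O)C[C@@H](C)CN(C)[C@H](C)[C@@H](O)[C@]1(C)O`, and compound 2, `CC[C@H]1OC(=O)[C@H](C)[C@@H](O)[C@H](C)[C@@H](O[C@@H]2O[C@H](C)C[C@H](N(C)C)[C@H]2OCCCNC(=O)CNc2ccnc3ccccc23)[C@](C)(O)C[C@@H](C)CN(C)[C@H](C)[C@@H](O)[C@]1(C)O`, share one core and differ by hydrogen in place of chloro on an aromatic carbon. In a physicochemical assay for solubility, at pH 4 (a lower number here means a less soluble compound, a higher number a more soluble compound), compound 1 gives > 10000 ug/mL, which is a limit of the assay and not a number. In this assay compound 2 gives > 10000 ug/mL, likewise a limit. The step that the two limits leave unreadable from compound 1 to compound 2 is therefore not readable in size.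

Compound 3, `CC[C@H]1OC(=O)[C@H](C)[C@@H](O[C@H]2C[C@@](C)(OC)[C@@H](O)[C@H](C)O2)[C@H](C)[C@@H](O[C@@H]2O[C@H](C)C[C@H](N(C)C)[C@H]2OCCCNc2ccnc3cc(Cl)ccc23)[C@](C)(O)C[C@@H](C)CN(C)[C@H](C)[C@@H](O)[C@]1(C)O`, carries a different core; the difference between the two cores is not broken down here. In this assay compound 3 gives > 10000 ug/mL, again a limit. What the three measured compounds have in common is the limit of > 10000 ug/mL in this assay, at which 3 of the 3 values shown sit.

Compound 4, `CC[C@H]1OC(=O)[C@H](C)[C@@H](O[C@H]2C[C@@](C)(OC)[C@@H](O)[C@H](C)O2)[C@H](C)[C@@H](O[C@@H]2O[C@H](C)C[C@H](N(C)C)[C@H]2OCCCNc2ccnc3ccccc23)[C@](C)(O)C[C@@H](C)CN(C)[C@H](C)[C@@H](O)[C@]1(C)O`, has not been measured. It differs from compound 3 by hydrogen in place of chloro on an aromatic carbon, the same change as that from compound 1 to compound 2, at the same place on the same ring system. For compound 4 the step of a number no higher from compound 3 to compound 4 (the limit leaves the size open) is expected to be negligible, an expectation that rests on (the limit of > 10000 ug/mL in this assay, at which 3 of the 3 values shown sit), the limit shared by compounds 1, 2 and 3. Compound 4 is thus expected to give about 10000 ug/mL in this assay, most likely reported as a limit once more.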

Compound 4, solubility: > 10000 ug/mL
Compound 4 ended at the assay's limit; the forecaster's own chance of this, stated with the estimate: 85%; the middle value sits exactly at the limit.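

In this assay compound 4 gives > 10000 ug/mL, a limit of the assay and not a number. Compound 3 also stands at a limit, so no size can be read for the step between compound 3 and compound 4. The compounds shown leave open how soluble each one actually is, and whether hydrogen in place of chloro changes that at all: the limit of > 10000 ug/mL in this assay, at which 4 of the 4 values shown sit.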